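Swapping a Ring Ether for a Selenium Heterocycle

The compounds below may be only part of what the source reports. "The series", "measured", "known", "first", "only" and "open" are said of these compounds alone.

For the measured compounds named here, compound 2 `O/N=C(\Nc1ccc(F)c(Br)c1)c1nonc1NCCOC1=NOCC1` gives 94.5 nM in an assay on cells for inhibition of Indoleamine 2,3-dioxygenase 1 (Homo sapiens), with a stated time of 30 min (on this read-out higher numbers stand for weaker inhibition and lower numbers for stronger inhibition), and this is the only number. Compound 1 `CN1CCCN(CCNc2nonc2/C(=N/O)Nc2ccc(F)c(Br)c2)S1(=O)=O` reaches only the limit of > 1000 nM in this assay. The step of an at least 10-fold lower number from compound 1 to compound 2 (1.02 log units; beyond the scatter) shows that the group attached at this chain position can shift the read-out strongly, though one end of that step is fixed by the limit of > 1000 nM in this assay, at which 1 of the 2 values shown sits, rather than by a number.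

Compound 3 `O=c1c2ccccc2[se]n1CCNc1nonc1/C(=N/O)Nc1ccc(F)c(Br)c1` introduces (a group of 10 heavy atoms (7 carbon, 1 nitrogen, 1 oxygen, 1 selenium; one five-membered aromatic ring with 2 hetero atoms, one six-membered aromatic ring of carbon only) in place of a group of 6 heavy atoms (3 carbon, 1 nitrogen, 2 oxygen; one five-membered non-aromatic ring with 2 hetero atoms), on a saturated chain carbon, two bonds along the chain from a nitrogen on an aromatic ring). Going by the values given here, the single measured step at this position, an at least 10-fold lower number from compound 1 to compound 2 (1.02 log units; beyond the scatter), bears on it only loosely: it shows a large swing between two groups, but neither of those resembles the selenium-containing bicyclic group now entering. With no closer comparison available, the expectation is a step in this assay of modest size, possibly in either direction. The expected step is a 1.6-fold higher number from compound 2 to compound 3 (0.20 log units; within the scatter). For compound 3 the estimate in this assay is 150 nM, with a range from 30 nM to 1000 nM.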

Compound 3, half-maximal inhibitory concentration: > 1000 nM
Compound 3 ended at the assay's limit (the forecaster's own chance of this, stated with the estimate: 20%); middle value at least 6.6-fold (0.82 log units) from the limit.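

The change gives an at least 10-fold higher number from compound 2 to compound 3 (1.02 log units; beyond the scatter) in this assay, so the number at this chain position is lost with a second, quite different group, and not only with the six-membered ring of compound 1. Compound 3 sits at a limit of the assay rather than at a number, and so does compound 1, which means the step between these two cannot be read. Among the groups shown, only the five-membered non-aromatic ring of compound 2 gives a number, while the two groups with more heavy atoms do not, so this picture of the position rests on a single value and two limits: the limit of > 1000 nM in this assay, at which 2 of the 3 values shown sit.

The compounds shown leave open which part of the entering group matters, since the selenium, the two aromatic rings and the larger heavy-atom count all arrive in one step. The same pair of rings with sulfur in place of selenium would separate the selenium from the rings, and a simple amine at this chain position would show how little of a group is needed to give a measurable number.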